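A few compounds are considered here, and "the series" means these few. Any claim that something is new, unique, unknown or untested is made for them only; others in the source may bear on it.

Working notes on the series. Two members of this series have been measured in a functional assay on HCT-116 cells (Homo sapiens) for inhibition; on this read-out higher numbers stand for an effect only at larger amounts of compound and lower numbers for an effect already at smaller amounts. Compound 1 `COc1cc(N2CCNCC2)ccc1Nc1nc(NC2CCCCC2)c2nc[nH]c2n1` carries an unsubstituted piperazine on the shared core and in this assay gives 160 nM. Compound 2 `COc1cc(N2CCC(C(=O)N3CCOCC3)CC2)ccc1Nc1nc(NC2CCCCC2)c2nc[nH]c2n1` carries a (morpholin-4-yl)carbonyl on a saturated ring carbon of a six-membered non-aromatic ring with 1 nitrogen, and in this assay compound 2 gives 130 nM. On these two numbers compound 2 stands alongside compound 1: the gap between them falls within the usual scatter of repeated measurements, so the two values are best read as the same result.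

Compound 3 `COc1cc(N2CCC(CC(=O)N3CCCC3)CC2)ccc1Nc1nc(NC2CCCCC2)c2nc[nH]c2n1` is the next member awaiting a number in this assay. It differs from compound 2 by ((pyrrolidin-1-yl)carbonyl)methyl in place of (morpholin-4-yl)carbonyl on a saturated ring carbon: a (pyrrolidin-1-yl)carbonyl reached through a methyl takes the place of the (morpholin-4-yl)carbonyl. Among the compounds with values here, no measured pair exists for a change of this kind, so nothing in the data fixes its direction. Both groups carry one amide carbonyl with the same count of heavy atoms. The step from compound 2 to compound 3 is expected to be a 1.2-fold higher number from compound 2 to compound 3 (0.06 log units; within the scatter), that is, none beyond the scatter. Compound 3 is therefore estimated at 150 nM, with a range of 60 nM to 400 nM.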

Compound 3, half-maximal effective concentration: 26 nM
The estimate for compound 3 lay 5.8-fold (0.76 log units) above the measured number; measured number below the stated range.
By their numbers in this assay, from the lowest: compound 3; then compounds 2 and 1 (each within the scatter of the next).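

In this assay, within the data shown here, the saturated ring carbon three ring bonds from the ring nitrogen responds to the group it carries: ((pyrrolidin-1-yl)carbonyl)methyl in place of (morpholin-4-yl)carbonyl gives a 5.0-fold lower number from compound 2 to compound 3 (0.70 log units; beyond the scatter), the first step at this position and one beyond the scatter. The step comes with no change in the heavy-atom count and with one amide carbonyl kept on each side, so neither of those counted features separates the two groups; what does change is the six-membered ring with 2 hetero atoms giving way to a five-membered ring with 1 hetero atom, one hydrogen-bond acceptor fewer, and a methyl now linking the carbonyl to the ring carbon. Nothing available bears on the reason for this step.

These changes arrive together, so the compounds shown leave open whether the step follows the methyl link or the change of amide ring. On these data alone, a (morpholin-4-yl)carbonyl reached through a methyl, a directly attached (pyrrolidin-1-yl)carbonyl, and a carboxylic acid or a longer chain at this ring carbon remain open questions.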